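Ring contraction of the basic amine on the shared core

The source may hold more compounds than are shown below. What is called first, only, known or untested is meant among the compounds shown, and "the series" means these compounds.

Compound 1 `Cn1nc(CN2CCCCC2)nc1-c1ccc(C(C)(C)C)cc1` and compound 2 `Cn1nc(CN2CCC(Cc3ccccc3)CC2)nc1-c1ccc(C(C)(C)C)cc1` share one core and differ only at the saturated ring. Going by the values given here, in an assay on membranes from brain for displacement of a labelled ligand from Sigma non-opioid intracellular receptor 1 (Cavia porcellus), read by scintillation counting, with a stated time of 1 h (on this read-out lower numbers stand for stronger inhibition and higher numbers for weaker inhibition), compound 1 gives 3.7 nM, the higher of the two numbers measured so far, and compound 2 gives 2 nM. Among the compounds with values here, the single measured step, a 1.9-fold lower number from compound 1 to compound 2 (0.27 log units; within the scatter), adds benzyl on a saturated ring carbon and leaves the ring size untouched, so the two measured compounds stand within the scatter of each other.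

Compound 3 `Cn1nc(CN2CCCC2)nc1-c1ccc(C(C)(C)C)cc1` differs from compound 1 by pyrrolidin-1-yl in place of piperidin-1-yl on a saturated chain carbon bound to an aromatic carbon. Within the data shown here, no measured step bears on this change: the step from compound 1 to compound 2 concerns a substituent on the ring and not the ring itself. Both measured numbers lie close together, which gives no sign that the ring region is sensitive, but nothing measured tests ring size directly. The expected step is therefore a 1.4-fold higher number from compound 1 to compound 3 (0.13 log units; within the scatter) in this assay, no change beyond the scatter, with a deliberately wide range. Compound 3 is estimated at 5 nM in this assay, between 1.5 nM and 18 nM.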

Compound 3, inhibition constant: 2.7 nM
The estimate for compound 3 lay 1.9-fold (0.27 log units) above the measured number, and the stated range covers the measured number.
By their numbers in this assay, from the lowest: compounds 2, 3 and 1 (each within the scatter of the next).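

In this assay, going by these compounds alone, the replacement of piperidin-1-yl by pyrrolidin-1-yl on a saturated chain carbon bound to an aromatic carbon gives a 1.4-fold lower number from compound 1 to compound 3 (0.14 log units; within the scatter) and so provides the first direct reading on the ring itself, not on a substituent carried by it. The five-membered and six-membered non-aromatic rings therefore cannot be told apart in this assay, and this holds alongside a 1.9-fold lower number from compound 1 to compound 2 (0.27 log units; within the scatter) as a second change at the amine of compound 1 that stays within the scatter. No available evidence accounts for this reading at either ring size.

Still open, from the compounds shown here alone, is whether the same reading would hold for a larger azepan-1-yl ring, for a ring with a second hetero atom such as morpholin-4-yl or piperazin-1-yl, or for an open-chain amine such as dimethylamino in the same place. Also open, going by these compounds, is how benzyl on a saturated ring carbon would read on the pyrrolidin-1-yl ring of compound 3, and whether any change at this amine moves the number beyond the scatter.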